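This account rests on a few compounds, and the source may have more. Where it says the series, first, only, none or still open, it means among the compounds named here.

Compound 1 `COc1ccc2c(=O)c(/C=C/C(=O)Nc3ccccc3Cl)coc2c1` is one of two compounds that have been examined in a functional assay on L02 cells (Homo sapiens) for inhibition, read by MTT assay, with a stated time of 48 h; on this read-out lower numbers stand for stronger inhibition and higher numbers for weaker inhibition. In this assay compound 1 gives only a limit, > 200000 nM, and no number. Compound 2 `Cc1ccccc1NC(=O)/C=C/c1coc2cc(O)ccc2c1=O` is the other measured compound. In this assay compound 2 likewise gives only a limit, > 200000 nM. Among the measured compounds shown here, both values therefore sit at the limit of > 200000 nM in this assay, at which 2 of the 2 values shown sit, so compound 1 stands at the same limit as the only other measured compound, and no order between compound 1 and compound 2 can be read from the numbers. For the measured compounds named here, no step between two measured compounds is available here, since neither value is a number.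

Compound 3 `COc1ccc2c(=O)c(/C=C/C(=O)NCc3ccc(F)cc3F)coc2c1` has not yet been measured in this assay. It differs from compound 1 in one place: 2,4-difluorobenzyl in place of 2-chlorophenyl on an amide-type nitrogen. With both measured compounds resting at the limit, compound 3 is expected to show no step beyond the scatter in either direction, the expected change being a number no higher from compound 1 to compound 3 (the limit leaves the size open). Compound 3 is thus estimated to give about 200000 nM, with a range from 80000 nM to 500000 nM, and most likely only a limit again.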

Compound 3, half-maximal inhibitory concentration: > 200000 nM
Compound 3: a limit, no number (the forecaster's own chance of this, stated with the estimate: 75%); the middle value sits exactly at the limit.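

In this assay compound 3 gives > 200000 nM as a limit and not a number. Among the compounds shown here, compound 1 also gives only a limit, so no step from compound 1 to compound 3 can be read: the limit of > 200000 nM in this assay, at which 3 of the 3 values shown sit.

The compounds shown leave open what number any of them would give, and whether 2,4-difluorobenzyl in place of 2-chlorophenyl changes inhibition at all.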